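Trimming the Methyl from the Ring Nitrogen

The source may report more compounds than this note shows. Statements on the series, on what has been measured and on what is new or still open speak of the compounds shown alone.

Compound 1 `OCCNc1[nH]ccc2ncnc1-2` and compound 2 `CNc1[nH]ccc2ncnc1-2` share one core. In a functional assay on EL4 cells (Mus musculus) for inhibition, tested at 100 uM (a lower number here means less inhibition, a higher number more inhibition at the concentration tested (going by the name of the read-out)), compound 1 gives < 5%, a limit of the assay rather than a number. In this assay compound 2 gives < 5%, again only a limit. The step that the two limits leave unreadable from compound 1 to compound 2 thus cannot be read, since both values sit at the limit of < 5% in this assay, at which 2 of the 2 values shown sit. Compound 3 `Nc1[nH]ccc2ncnc1-2` differs from compound 2 by hydrogen in place of methyl on a nitrogen on an aromatic ring. Among the compounds with values here, no measured step tells how this change acts. For compound 3 the expected step is a step that the limit leaves unreadable from compound 2 to compound 3, none beyond the scatter. Compound 3 is therefore estimated at 3%, between 0% and 10%, most likely again reported only as a limit.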

Compound 3, a percentage reported as inhibition, at one concentration (the size of the read-out at that concentration, not a potency): < 5%
Compound 3: a limit, no number (the forecaster's own chance of this, stated with the estimate: 85%); the middle value does not contradict the limit.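

No step among compound 1, compound 2 and compound 3 can be read, since all three values are limits, not numbers: the limit of < 5% in this assay, at which 3 of the 3 values shown sit.

In this assay no compound shown gives a number, so how any change on the shared core affects inhibition stays open.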